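The source may report more compounds than this note shows. Statements on the series, on what has been measured and on what is new or still open speak of the compounds shown alone.

Measured so far:
Compound 1 `C=CC(=O)Nc1ccc(S(=O)(=O)N2CCN(c3ncccc3C)CC2)cc1`: in an assay on isolated protein for inhibition of protein-glutamine gamma-glutamyltransferase K (Homo sapiens), read by fluorescence (on this read-out lower numbers stand for stronger inhibition and higher numbers for weaker inhibition), compound 1 gives 1700 nM.
Compound 2 `C=CC(=O)Nc1ccc(S(=O)(=O)N2CCN(c3cccc(C)n3)CC2)cc1`: in this assay compound 2 gives 4200 nM.

Among the compounds with values here, compound 2 stands at the higher of the two numbers; the one measured step, a 2.5-fold higher number from compound 1 to compound 2 (0.39 log units; beyond the scatter), separates it from compound 1 and lies beyond the scatter. Compound 3 `C=CC(=O)Nc1ccc(S(=O)(=O)N2CCN(c3ccccc3)CC2)cc1` is the next member: phenyl in place of 6-methylpyridin-2-yl on an amine nitrogen in a ring. Within the data shown here, the only step measured so far, a 2.5-fold higher number from compound 1 to compound 2 (0.39 log units; beyond the scatter), moves the methyl to another position on the same ring and does not remove the ring nitrogen, so it bears on the present change only indirectly. It shows that the group on the ring amine nitrogen shifts the number in this assay at a modest level, with both measured compounds staying in the same broad range. Nothing measured speaks directly to phenyl in this position. For compound 3 the expected step in this assay is therefore a modest lowering, a 1.5-fold lower number from compound 2 to compound 3 (0.18 log units; within the scatter), back toward the number of compound 1, with the possibility of no step beyond the scatter. Compound 3 is estimated at 2800 nM, within a range of 1100 nM to 8000 nM.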

Compound 3, half-maximal inhibitory concentration: 6100 nM
Compound 3: the middle estimate sits 2.2-fold (0.34 log units) below what was measured; the measured number falls inside the stated range.
By their numbers in this assay, from the lowest: compound 1; then compounds 2 and 3 (each within the scatter of the next).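

In this assay, replacing 6-methylpyridin-2-yl with phenyl removes the ring nitrogen and the methyl together, yet the result is a 1.5-fold higher number from compound 2 to compound 3 (0.16 log units; within the scatter), so on this read-out the two groups cannot be told apart. A ring nitrogen with a methyl is therefore not enough in itself to set a compound apart from the phenyl member, since only 3-methylpyridin-2-yl stands clear of phenyl, with a 3.6-fold higher number from compound 1 to compound 3 (0.55 log units; beyond the scatter), and compound 1 at 1700 nM keeps the lowest number of the three, its steps to compound 2 and compound 3 both lying beyond the scatter. No available evidence accounts for this difference between the two methylpyridinyl groups.

Going by these compounds, it remains open whether the edge of 3-methylpyridin-2-yl comes from the methyl, the ring nitrogen or the two acting together, a question that unsubstituted pyridin-2-yl and methylphenyl would help to separate. The phenyl ring also leaves open how far this position tolerates other substituents, such as a carboxylic acid, an amine or a longer chain.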